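Aryl swap on the shared core: compound 3 to compound 4

The source may report more compounds than this note shows. Statements on the series, on what has been measured and on what is new or still open speak of the compounds shown alone.

Compound 1 `O=C(O)Cc1sc(C(c2ccc(F)cc2)c2ccc(F)cc2)nc1-c1ccc(Cl)cc1`, compound 2 `CS(=O)(=O)Nc1cccc(-c2nc(C(c3ccc(F)cc3)c3ccc(F)cc3)sc2CC(=O)O)c1` and compound 3 `O=C(O)Cc1sc(C(c2ccc(F)cc2)c2ccc(F)cc2)nc1-c1ccoc1` share one core and differ only in the aromatic group attached to an aromatic carbon. In an in vitro functional assay on HEK285-7 cells for antagonist activity at prostaglandin D2 receptor 2 (Homo sapiens), read by BRET and beta-arrestin recruitment (a lower number here means a stronger inhibitor, a higher number a weaker inhibitor), compound 1 gives 180 nM, compound 2 gives 370 nM and compound 3 gives 130 nM, the lowest of the three numbers. The relevant steps are a 1.4-fold lower number from compound 1 to compound 3 (0.14 log units; within the scatter) and a 2.8-fold lower number from compound 2 to compound 3 (0.45 log units; beyond the scatter), while a 2.1-fold higher number from compound 1 to compound 2 (0.31 log units; beyond the scatter). Compound 4 `Cc1cc(-c2nc(C(c3ccc(F)cc3)c3ccc(F)cc3)sc2CC(=O)O)ccn1` carries the change (2-methylpyridin-4-yl in place of furan-3-yl on an aromatic carbon). Among the measured compounds shown here, no measured step covers a six-membered aromatic ring with one nitrogen at this position, so only the spread among compounds 1, 2 and 3 guides the expectation. For compound 4 a small shift is expected, a 1.5-fold higher number from compound 3 to compound 4 (0.19 log units; within the scatter), giving an estimated 200 nM with a range of 80 nM to 500 nM in this assay.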

Compound 4, half-maximal inhibitory concentration: 53 nM
Estimate against measurement, compound 4: 3.8-fold (0.58 log units) above, outside the stated range (below it).
By their numbers in this assay, from the lowest: compound 4; then compounds 3 and 1 (each within the scatter of the next); then compound 2.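

In this assay, 2-methylpyridin-4-yl is the only group shown that separates from both furan-3-yl and 4-chlorophenyl, with a 2.5-fold lower number from compound 3 to compound 4 (0.39 log units; beyond the scatter) and a 3.4-fold lower number from compound 1 to compound 4 (0.53 log units; beyond the scatter); those two groups had stayed within the scatter of each other. The largest step at this position is now a 7.0-fold lower number from compound 2 to compound 4 (0.84 log units; beyond the scatter), so compound 4 is the strongest inhibitor of the four. No available evidence bears on the reason for these steps.

Still open, from the compounds shown here alone, is whether the ring nitrogen or the methyl group carries the step. Pyridin-4-yl without the methyl group, set against a methylphenyl group, would separate the two.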